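Working notes: chloro for bromo in compound 1

A few compounds are considered here, and "the series" means these few. Any claim that something is new, unique, unknown or untested is made for them only; others in the source may bear on it.

- compound 1 `O=C(Nc1cc(C(F)(F)F)cc(C(F)(F)F)c1)c1ccc(Br)cc1O` gives 1200 nM in the test below
- compound 2 `O=C(Nc1cc(Cl)cc(Cl)c1)c1cc(F)ccc1O` gives 1440 nM in the same test

Both numbers come from a functional assay on NALM-6 cells (Homo sapiens) for cytotoxicity, read by luminescence and CellTiter-Glo, with a stated time of 3 days (on this read-out higher numbers stand for weaker inhibition and lower numbers for stronger inhibition), and lie within the usual scatter of each other, so compound 1 stands level with compound 2 and the two cannot be ranked. For the measured compounds named here, these two compounds differ in more than one place, so the series offers no measured single-change step to lean on.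

The next compound to be read is compound 3 `O=C(Nc1cc(C(F)(F)F)cc(C(F)(F)F)c1)c1ccc(Cl)cc1O` which has chloro in place of bromo on an aromatic carbon, meta to a hydroxy group and para to a large group (chloro in place of bromo on an aromatic carbon) while the rest of compound 1 stays unchanged. Cut one bond further out, the change reads 4-bromo-2-hydroxyphenyl to 4-chloro-2-hydroxyphenyl.

Going by the values given here, with compound 1 at 1200 nM as the anchor, and with no measured step to suggest a direction, no change beyond the scatter is expected in this assay for this swap. The estimated 1.1-fold higher number from compound 1 to compound 3 (0.03 log units; within the scatter) stays within the usual scatter. Compound 3 is estimated at 1300 nM with 550 nM to 3000 nM as its expected range.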

Compound 3, half-maximal inhibitory concentration: 850 nM
Beside the measured number, compound 3's estimate is 1.5-fold (0.18 log units) above it, within the range that was stated.
By their numbers in this assay, from the lowest: compounds 3, 1 and 2 (each within the scatter of the next).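

Working notes, continued: In this assay, the swap of bromo for chloro on this aromatic carbon, meta to a hydroxy group and para to a large group, gives a 1.4-fold lower number from compound 1 to compound 3 (0.15 log units; within the scatter) and supplies the first single-change step in the series. Compound 1 and compound 3 therefore stand level, and bromo and chloro cannot be told apart at this position on this read-out, with the rest of compound 1 held constant. Nothing available bears on the reason for this result.

As far as these compounds go, the comparison covers only two halogens at this carbon, so it remains open whether a group such as an amine, a carboxylic acid or a longer chain there would shift the number beyond the scatter. Compound 2 differs from compound 1 and compound 3 in more than one place, so the separate contributions of its other changes remain unresolved.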